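This account rests on a few compounds, and the source may have more. Where it says the series, first, only, none or still open, it means among the compounds named here.

Compound 1 `Cn1c(-c2ccc(NC(=O)CSc3nc4ccccc4o3)cc2)nc(-c2ccccc2)c1-c1ccccc1` gives 71.5% in a functional assay on MCF7 cells (Homo sapiens) for cytotoxicity, read by MTT assay, with a stated time of 24 h, tested at 32 ug/mL; on this read-out lower numbers stand for a weaker effect and higher numbers for a stronger effect at the one concentration tested. Compound 2 `Cc1ccc2oc(SCC(=O)Nc3ccc(-c4nc(-c5ccccc5)c(-c5ccccc5)n4C)cc3)nc2c1` gives 57.7% in this assay. Compound 3 `Cn1cnnc1SCC(=O)Nc1ccc(-c2nc(-c3ccccc3)c(-c3ccccc3)n2C)cc1` gives 89.2% in this assay.

Compound 3 stands highest of the three numbers, with compound 1 nearest and compound 2 furthest, both beyond the scatter. The measured steps are a number 13.8 percentage points lower from compound 1 to compound 2 (beyond the scatter), a number 17.7 percentage points higher from compound 1 to compound 3 (beyond the scatter) and a number 31.5 percentage points higher from compound 2 to compound 3 (beyond the scatter).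

Compound 4 `CN(C)/C=C/N1CCN(CC(=O)Nc2ccc(-c3nc(-c4ccccc4)c(-c4ccccc4)n3C)cc2)CC1` differs from compound 3 in one place: 4-(2-(dimethylamino)ethenyl)piperazin-1-yl in place of (4-methyl-4H-1,2,4-triazol-3-yl)sulfanyl on a saturated chain carbon bound to a carbonyl carbon. The two steps that reach compound 3 exchange one heteroaryl on the sulfur for another and were modest to large; the step from compound 1 to compound 2 was modest. None of the three steps removes the sulfur link itself or brings in a non-aromatic ring, so they bear on the new change only loosely. A step beyond the scatter is expected in this assay, more likely downward from the high standing of compound 3 than upward, with wide uncertainty. For compound 4 the estimated step is a number 24.2 percentage points lower from compound 3 to compound 4 (beyond the scatter), giving an expected value of 65% within 35% to 90%.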

Compound 4, a percentage reported as activity, at one concentration (the size of the read-out at that concentration, not a potency): 25.8%
Compound 4: the middle estimate sits 39.2 percentage points above what was measured; measured number outside the range, below it.
By their numbers in this assay, from the lowest: compound 4; then compound 2; then compound 1; then compound 3.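

Until now, the changes at this position only exchanged one heteroaryl group on the sulfur, whereas 4-(2-(dimethylamino)ethenyl)piperazin-1-yl replaces the sulfur and its aromatic ring together, and in this assay this gives a number 63.4 percentage points lower from compound 3 to compound 4 (beyond the scatter). The same exchange gives a number 45.7 percentage points lower from compound 1 to compound 4 (beyond the scatter) and a number 31.9 percentage points lower from compound 2 to compound 4 (beyond the scatter), so all three sulfur-linked compounds shown stand above compound 4, whichever heteroaryl they carry. No measurement shown here accounts for this result.

The change alters the sulfur link, the ring and the ethenyl chain at once, so the compounds shown do not separate what each part contributes. On these data alone, it remains open whether a plain piperazin-1-yl, a morpholine or a 4-methyl-4H-1,2,4-triazol-3-yl joined without the sulfur would stay nearer compound 3 or compound 4.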